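Adding a second methyl to the 3-methylphenyl ring

This account rests on a few compounds, and the source may have more. Where it says the series, first, only, none or still open, it means among the compounds named here.

Measured so far in an ADME assay on HepG2 2.2.15 cells (Homo sapiens) for cytotoxicity, read by CCK-8 assay, with a stated time of 8 days; on this read-out higher numbers stand for lower toxicity in this test and lower numbers for higher toxicity in this test:
- compound 1 `Cc1cccc(-c2cc(NC(=O)c3ccccc3O)c[nH]c2=O)c1`: 98800 nM
- compound 2 `CCOc1ccc(-c2cc(NC(=O)c3ccccc3O)c[nH]c2=O)cc1`: 41000 nM
- compound 3 `CCOc1ccc(-c2cc(NC(=O)c3ccc(C)cc3O)c[nH]c2=O)cc1`: > 100000 nM

The number for compound 3 is a limit of this assay, not a measured number.

Compounds 1 and 2 share a core but differ in the ring that hangs from it; the difference between the two cores is not broken down here. Of the two numbers, compound 1 gives the higher one, and the gap between them lies beyond the usual scatter.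

From compound 2 to compound 3 the change is methyl in place of hydrogen on an aromatic carbon; it gave an at least 2.4-fold higher number from compound 2 to compound 3 (0.38 log units; beyond the scatter), though as one end of that step is a limit, its true size is open (the limit of > 100000 nM in this assay, at which 1 of the 3 values shown sits).

Compound 4 `Cc1cc(C)cc(-c2cc(NC(=O)c3ccccc3O)c[nH]c2=O)c1` is not yet measured. It differs from compound 1 by methyl in place of hydrogen on an aromatic carbon. This is the same kind of change as that from compound 2 to compound 3, but the surroundings differ: in compound 3 the new methyl sits meta to a hydroxy group and para to a large group, whereas in compound 4 it sits meta to a large group and meta to a methyl group.

Resting on the rise seen in an at least 2.4-fold higher number from compound 2 to compound 3 (0.38 log units; beyond the scatter) and on the starting point of compound 1 at 98800 nM, compound 4 is expected to show a 1.6-fold higher number from compound 1 to compound 4 (0.21 log units; within the scatter). Compound 4 is estimated at 160000 nM in this assay, between 70000 nM and 400000 nM, and a limit rather than a number is a real possibility.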

Compound 4, half-maximal cytotoxic concentration: 25100 nM
For compound 4 the middle estimate is 6.4-fold (0.80 log units) above the measured one, and the stated range ends above it.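

In this assay the methyl that turns 3-methylphenyl into 3,5-dimethylphenyl gave a 3.9-fold lower number from compound 1 to compound 4 (0.60 log units; beyond the scatter), so on this read-out compound 4 is the more toxic of the pair. This is the opposite direction to the earlier step, which shows that in this series the effect of adding a methyl to an aromatic carbon does not carry over reliably from one core to another, not even in its sign: the same change on two cores in this assay, an at least 2.4-fold higher number (0.38 log units; beyond the scatter) from compound 2 to compound 3 and a 3.9-fold lower number (0.60 log units; beyond the scatter) from compound 1 to compound 4, at least 9.6-fold (0.98 log units) apart, beyond the scatter of two such steps. The value of compound 3 is a limit and not a number, and two steps, with the methyl placed on different rings of different compounds, do not show whether the surroundings of the new methyl or the rest of the molecule set the outcome: the limit of > 100000 nM in this assay, at which 1 of the 4 values shown sits.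

Left open is what the same methyl would do on compound 1 at the place it occupies in compound 3, a comparison that would keep the rest of the molecule fixed while testing that position. Also open, from the compounds shown here alone, is whether a different group at the new place on the 3-methylphenyl ring, such as a chlorine atom, a longer chain like propyl, or an amine, would move the number the same way as the methyl in compound 4.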